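The compounds below may be only part of what the source reports. "The series", "measured", "known", "first", "only" and "open" are said of these compounds alone.

Measured in a functional assay on MT4 cells (Homo sapiens) for inhibition; on this read-out higher numbers stand for weaker inhibition and lower numbers for stronger inhibition:
- Compound 1 `C=C1[C@@H](O)[C@H](n2ccc(=O)[nH]c2=O)O[C@@H]1CO`: 450000 nM
- Compound 2 `C=C1[C@@H](O)[C@H](n2ccc(N)nc2=O)O[C@@H]1CO`: 121000 nM
- Compound 3 `C=C1[C@@H](O)[C@H](n2cnc3c(O)nc(N)nc32)O[C@@H]1CO`: > 200000 nM

For compound 3 the assay gives only a limit, > 200000 nM, and not a number. Compound 4 `C=C1[C@@H](O)[C@H](n2cnc3c(SC)nc(N)nc32)O[C@@H]1CO` has methylsulfanyl in place of hydroxy on an aromatic carbon. Within the data shown here, no measured pair in this set shows that swap, so the expectation rests on the general level of the values. With compound 1 at 450000 nM and compound 2 at 121000 nM, inhibition stays weak in this assay, so only a modest move towards stronger inhibition is expected. The expected change is an at least 1.3-fold lower number from compound 3 to compound 4 (0.12 log units; that floor lies within the scatter). Compound 4 is estimated at 150000 nM, with an expected range of 40000 nM to 400000 nM.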

Compound 4, half-maximal inhibitory concentration: > 500000 nM
Compound 4: no number, only a limit; the forecaster's own chance of this, stated with the estimate: 45%; middle value at least 3.3-fold (0.52 log units) away from the limit.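

Among these compounds, compound 3 and compound 4 each have only a limit in this assay, not a number, and no step between them can be read. As far as these compounds go, whether methylsulfanyl in place of hydroxy on an aromatic carbon strengthens or weakens inhibition stays open.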